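Flipping One Ring Stereocentre in a Three-Compound Series

This account rests on a few compounds, and the source may have more. Where it says the series, first, only, none or still open, it means among the compounds named here.

In a functional assay on P388 cells (Mus musculus) for inhibition, with a stated time of 48 h, tested at 0.1 ug/mL (a lower number here means a weaker effect, a higher number a stronger effect of the compound at the concentration tested), compound 1 `C=C1C(=O)O[C@H]2CCCCC[C@@H]12` gives 9%. Putting a methyl in place of a hydrogen on a saturated ring carbon yields compound 2 `C=C1C(=O)O[C@H]2CC[C@H](C)CC[C@@H]12`, which gives 15%; the step is a number 6 percentage points higher from compound 1 to compound 2 (within the scatter). Compound 3 `C=C1C(=O)O[C@H]2[C@@H](OC(C)=O)CCCC[C@@H]12`, carrying an acetoxy instead, gives 9%; that step is no change at the digits printed from compound 1 to compound 3 (within the scatter). Compound 2 thus holds the highest of the three numbers, though both others lie within the scatter of it. Compound 4 `C=C1C(=O)O[C@H]2CC[C@@H](C)CC[C@@H]12` differs from compound 2 only as follows: the two compounds have the same atoms and bonds and differ only in configuration as drawn: 1 of 3 stereo elements differ; a stereocentre at a saturated ring carbon is drawn R in compound 2 and S in compound 4. Among the measured compounds shown here, no measured step alters a configuration, and the two steps seen were both within the scatter, so for compound 4 the expected step is a number 3 percentage points lower from compound 2 to compound 4 (within the scatter), nothing beyond the scatter. Compound 4 is therefore estimated at 12%, between 3% and 25%.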

Compound 4, a percentage reported as activity, at one concentration (the size of the read-out at that concentration, not a potency): 38%
Compound 4: the middle estimate sits 26 percentage points below what was measured; the measured number lies above the stated range.
By their numbers in this assay, from the lowest: compounds 1, 3 and 2 (each within the scatter of the next); then compound 4.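

Reversing one stereocentre gives a number 23 percentage points higher from compound 2 to compound 4 (beyond the scatter) in this assay even though no atom changes. Methyl in place of hydrogen, which stayed within the scatter when drawn R, gives a number 29 percentage points higher from compound 1 to compound 4 (beyond the scatter) when drawn S. At this ring carbon, then, the presence of a methyl is not enough on its own and its configuration decides the outcome, because of this: the fact that compounds 2 and 4 differ only in the configuration as drawn

The compounds shown leave open whether an ethyl or a hydroxyl on this carbon would show the same dependence on configuration. They also leave open whether the acetoxy group would respond to such a reversal at its own position.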